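Bromo to Fluoro on a Second Core

The source may hold more compounds than are shown below. What is called first, only, known or untested is meant among the compounds shown, and "the series" means these compounds.

Compound 1 `CC(=O)Oc1ccc(/C=C/C(=O)OCCSc2nc(-c3ccc(S(N)(=O)=O)cc3)n(-c3ccc(Br)cc3)n2)cc1OC(C)=O`: 1050 nM
Compound 2 `CC(=O)Oc1ccc(/C=C/C(=O)OCCSc2nc(-c3ccc(S(N)(=O)=O)cc3)n(-c3ccc(F)cc3)n2)cc1OC(C)=O`: 1060 nM
Compound 3 `CC(=O)Oc1ccc(/C=C/C(=O)NCCCSc2nc(-c3ccc(S(C)(=O)=O)cc3)n(-c3ccc(Br)cc3)n2)cc1OC(C)=O`: 990 nM

Of the compounds shown here, three have been measured in an assay on cells (strain Sprague-Dawley) for inhibition of Polyunsaturated fatty acid 5-lipoxygenase (Rattus norvegicus), with a stated time of 30 min; a lower number here means a stronger inhibitor, a higher number a weaker inhibitor; compound 1 gives 1050 nM, compound 2 gives 1060 nM, and compound 3 gives 990 nM. All three values lie within the scatter of one another. Compound 1 and compound 2 differ in one place, (fluoro in place of bromo on an aromatic carbon), and the step there is a 1.0-fold higher number from compound 1 to compound 2 (0.00 log units; within the scatter). Compound 4 `CC(=O)Oc1ccc(/C=C/C(=O)NCCCSc2nc(-c3ccc(S(C)(=O)=O)cc3)n(-c3ccc(F)cc3)n2)cc1OC(C)=O` has not been measured; it arises from compound 3 by fluoro in place of bromo on an aromatic carbon. The difference between the core of compound 1 and the core of compound 3 is not broken down here. The change from compound 3 to compound 4 is the same as that from compound 1 to compound 2, and on that core it left the value unchanged. For compound 4 a step of a 1.0-fold higher number from compound 3 to compound 4 (0.00 log units; within the scatter) is therefore expected, resting on the flat step a 1.0-fold higher number from compound 1 to compound 2 (0.00 log units; within the scatter). Compound 4 is estimated at 1000 nM, between 500 nM and 2000 nM.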

Compound 4, half-maximal inhibitory concentration: 980 nM
Compound 4: the middle estimate sits 1.0-fold (0.01 log units) above what was measured; the range from low to high includes it.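

In this assay the change from 4-bromophenyl to 4-fluorophenyl gives a 1.0-fold lower number from compound 3 to compound 4 (0.00 log units; within the scatter). Set beside the earlier step, the change carries from one core to the other with no difference that can be told apart: the same change on two cores in this assay, a 1.0-fold higher number (0.00 log units; within the scatter) from compound 1 to compound 2 and a 1.0-fold lower number (0.00 log units; within the scatter) from compound 3 to compound 4, 1.0-fold (0.01 log units) apart, within the scatter of two such steps. This shows that the swap is flat on both of these cores, but it does not show that it would be flat on any other core, nor why the value stays put.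

The compounds shown leave open whether a different group in that place, such as a methoxy, an amine or a carboxylic acid, would move the value. They also do not separate the differences between the core of compound 1 and the core of compound 3.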